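The source may report more compounds than this note shows. Statements on the series, on what has been measured and on what is new or still open speak of the compounds shown alone.

Measured compounds:
compound 1 `CCOc1ccc(-c2ccc(NCc3ccccc3O)cc2)cc1`, giving 520 nM in a functional assay on Jurkat cells (Homo sapiens) for activation, with a stated time of 24 h; on this read-out higher numbers stand for an effect only at larger amounts of compound and lower numbers for an effect already at smaller amounts
compound 2 `CCSc1ccc(-c2ccc(NCc3ccccc3O)cc2)cc1`, giving 1980 nM in this assay
compound 3 `CCOc1ccc(-c2ccc(NCc3ccccc3O)cn2)cc1`, giving "not active" (no number reported) in this assay, with no number given

Compound 1 and compound 2 share a core and differ in one place: ethylsulfanyl in place of ethoxy on an aromatic carbon. This change carries the step of a 3.8-fold higher number from compound 1 to compound 2 (0.58 log units; beyond the scatter), so the ethylsulfanyl compound sits noticeably weaker than its ethoxy counterpart in this assay.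

Compound 3 carries a different core from compound 1; the difference between the two cores is not broken down here. In this assay compound 3 was recorded as showing no activity, and no number was reported for it.

The unmeasured compound 4 `CCSc1ccc(-c2ccc(NCc3ccccc3O)cn2)cc1` stands to compound 3 as compound 2 stands to compound 1: ethylsulfanyl in place of ethoxy on an aromatic carbon. The place line is the same word for word in both pairs, so the change is the same one, made on the other core.

In this assay the change from compound 1 to compound 2 moved the number upward by a modest step. Since compound 3 already gave no number in this assay, the same change on its core is expected to leave compound 4 at least as far from activity. Compound 4 is therefore expected to be reported as not active, or, should a number appear, to lie around 30000 nM, with a range estimated from 8000 nM to 100000 nM.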

Compound 4, half-maximal effective concentration: 1920 nM
Beside the measured number, compound 4's estimate is 16-fold (1.19 log units) above it; measured number below the stated range.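

In this assay, among these compounds, compound 4 gives 1920 nM while compound 3 has no number, so no step from compound 3 to compound 4 can be read. The compounds shown leave open how far ethylsulfanyl in place of ethoxy shifts activity on the core of compound 3, and whether that shift matches the one on the core of compound 1. Nothing shown here gives a measured reason for this result.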